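The source may hold more compounds than are shown below. What is called first, only, known or untested is meant among the compounds shown, and "the series" means these compounds.

Working notes on the chalcone-triazole series.

Three compounds have numbers in a functional assay on A549 cells (Homo sapiens) for inhibition, read by MTT assay; a higher number here means a weaker inhibitor, a lower number a stronger inhibitor. Compound 1 `O=C(CN1CCC(Cc2ccccc2)CC1)Nc1ccc(C(=O)/C=C/c2cn(Cc3ccc(Br)cc3)nn2)cc1` gives 40000 nM in this assay. Compound 2 `O=C(CBr)Nc1ccc(C(=O)/C=C/c2cn(Cc3ccc(Br)cc3)nn2)cc1` gives 8670 nM in this assay, the lowest of the three numbers; compound 1 stands a step above it that is beyond the scatter, and compound 3 `CCCCCCCCCCn1cc(/C=C/C(=O)c2ccc(NC(=O)CN3CCN(c4ccccc4)CC3)cc2)nn1`, which gives 52100 nM in this assay, stands a further step above. Compound 2 thus carries the strongest inhibition shown so far, and it is also the only one bearing the bromoacetamide; compound 3, with a decyl chain on the aromatic nitrogen, sits at the weak end, though its amide portion differs as well, so no single-change comparison on the nitrogen substituent exists among the measured compounds.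

Compound 4 `CCCCCCCCn1cc(/C=C/C(=O)c2ccc(NC(=O)CBr)cc2)nn1` keeps the bromoacetamide of compound 2 and changes the group on the aromatic nitrogen: heptyl in place of 4-bromophenyl on a saturated chain carbon bound to an aromatic nitrogen. Within the data shown here, since compound 3, the only measured compound with a long chain on that nitrogen, gives 52100 nM in this assay, compound 4 is expected to lose some potency against compound 2, with a step of a 2.1-fold higher number from compound 2 to compound 4 (0.32 log units; beyond the scatter) that may be beyond the scatter. Compound 4 is estimated at 18000 nM, within a range of 6000 nM to 55000 nM.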

Compound 4, half-maximal inhibitory concentration: 11600 nM
The estimate for compound 4 lay 1.6-fold (0.19 log units) above the measured number; the range from low to high includes it.
By their numbers in this assay, from the lowest: compounds 2 and 4 (each within the scatter of the next); then compounds 1 and 3 (each within the scatter of the next).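

In this assay, among these compounds, placing heptyl in place of 4-bromophenyl on a saturated chain carbon bound to an aromatic nitrogen gives a 1.3-fold higher number from compound 2 to compound 4 (0.13 log units; within the scatter), the first single-change reading at this position. With the bromoacetamide held fixed, the aromatic ring and its bromine give way to an open chain without a change beyond the scatter, so the 4-bromobenzyl and octyl groups cannot be told apart in this measurement. Nothing at hand offers an explanation for this result.

From the compounds shown here alone, whether the same holds for a butyl group, a dodecyl group or a chain carrying a carboxylic acid at this place remains open, so the limits of what the position accepts are not yet defined. Also open, going by these compounds, is whether the 4-bromobenzyl and octyl groups would still read alike with another amide portion, such as a chloroacetamide, in place of the bromoacetamide.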